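The source may report more compounds than this note shows. Statements on the series, on what has been measured and on what is new or still open speak of the compounds shown alone.

Three compounds measured in an assay on isolated protein for inhibition of Gonadotropin-releasing hormone receptor (Rattus norvegicus) (on this read-out higher numbers stand for weaker inhibition and lower numbers for stronger inhibition), set the scene. Compound 1 `Cc1cccc(CSc2nc3cc(NC(=O)C4CC4)ccc3n2C(C)C)c1` carries an isopropyl group on the ring nitrogen of the shared core and a methyl-substituted benzyl sulfide; in this assay compound 1 returns only a limit, > 10000 nM. Compound 2 `COc1ccc(C(C)=O)cc1CSc1nc2cc(NC(=O)C3CC3)ccc2n1C(C)C` keeps the isopropyl group and adds an acetyl and a methoxy group to the benzyl ring; in this assay compound 2 likewise returns only a limit, > 10000 nM. Compound 3 `COc1ccc([N+](=O)[O-])cc1CSc1nc2cc(NC(=O)NC(C)(C)C)ccc2n1C1CC1` differs in several places at once: a nitro group and a methoxy group on the benzyl ring, a tert-butyl urea in place of the cyclopropyl amide, and a cyclopropyl group on the ring nitrogen. Among the measured compounds shown here, compound 3 is the only compound with an actual number, 860 nM. Compound 1 and compound 2, by contrast, sit at the limit of > 10000 nM in this assay, at which 2 of the 3 values shown sit.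

Compound 4 `CCCCCn1c(SCc2cc([N+](=O)[O-])ccc2OC)nc2cc(NC(=O)NC(C)(C)C)ccc21` changes one thing: pentyl in place of cyclopropyl on an aromatic nitrogen. For the measured compounds named here, no comparable step has been measured, so the expected step from compound 3 to compound 4 is a modest loss, a 1.7-fold higher number from compound 3 to compound 4 (0.24 log units; within the scatter). Compound 4 is therefore estimated at 1500 nM, within 400 nM to 6000 nM.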

Compound 4, half-maximal inhibitory concentration: 880 nM
The estimate for compound 4 lay 1.7-fold (0.23 log units) above the measured number, and the stated range covers the measured number.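

Moving from cyclopropyl to pentyl on this aromatic nitrogen gives, in this assay, a 1.0-fold higher number from compound 3 to compound 4 (0.01 log units; within the scatter), so the two numbers cannot be told apart. Among the compounds shown here, this is the first comparison in which only this position differs, and it shows that, with the rest of compound 3 held in place, the three-membered ring is not required here: an open pentyl chain with more carbon atoms serves equally well. Nothing shown explains why the two groups match.

From the compounds shown here alone, it remains open whether a chain on this nitrogen ending in an amine or a carboxylic acid, or a benzyl group in the same place, would match these two compounds. Going by these compounds, it is also open whether pentyl would do the same alongside the cyclopropyl amide of compound 1.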